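This account rests on a few compounds, and the source may have more. Where it says the series, first, only, none or still open, it means among the compounds named here.

In a functional assay on K562 cells (Homo sapiens) for cytotoxicity, read by MTT assay, with a stated time of 5 days (on this read-out higher numbers stand for weaker inhibition and lower numbers for stronger inhibition), compound 1 `COc1ccc(Cn2nncc2-c2cc(OC)c(OC)c(OC)c2)cc1` gives 8660 nM and compound 2 `COc1ccc(Cn2nncc2-c2cc(OC)c(OC)c(OC)c2)cc1O` gives 1830 nM. Among the compounds with values here, the only measured step between close relatives is hydroxy in place of hydrogen on an aromatic carbon, which gives a 4.7-fold lower number from compound 1 to compound 2 (0.68 log units; beyond the scatter). Compound 3 `COc1ccc(-c2cn(-c3cc(OC)c(OC)c(OC)c3)nn2)cc1` has a different core and reads > 10000 nM, which is a limit of the assay and not a number. Compound 4 `COc1ccc(-c2cn(-c3cc(OC)c(OC)c(OC)c3)nn2)cc1Br` differs from compound 3 by one change, bromo in place of hydrogen on an aromatic carbon, ortho to a methoxy group: bromo in place of hydrogen on an aromatic carbon. Within the data shown here, no bromo step has been measured in this assay, so the nearest guide is the hydroxy change from compound 1 to compound 2, with its modest 4.7-fold lower number from compound 1 to compound 2 (0.68 log units; beyond the scatter). It involves a different group on a different core, so it bears on this case only loosely. A modest move towards lower numbers is therefore expected, and compound 4 may still stay at the limit. The expected step is an at least 2.0-fold lower number from compound 3 to compound 4 (0.30 log units; that floor lies within the scatter). For compound 4 the estimated value is 5000 nM, with an expected range of 1000 nM to 15000 nM.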

Compound 4, half-maximal inhibitory concentration: > 10000 nM
Compound 4 ended at the assay's limit (the forecaster's own chance of this, stated with the estimate: 40%); at least 2.0-fold (0.30 log units) between middle value and limit.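

In this assay compound 3 and compound 4 both stand at a limit and not at a number, so no step between them can be read: the limit of > 10000 nM in this assay, at which 2 of the 4 values shown sit.

The compounds shown leave open whether bromo in place of hydrogen on an aromatic carbon changes the read-out at all, and by how much.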